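Trimming the chain of compound 1

The compounds below may be only part of what the source reports. "The series", "measured", "known", "first", "only" and "open" are said of these compounds alone.

Measured in a physicochemical assay for lipophilicity, measured as octanol-water partition; a lower number here means a more polar compound, a higher number a more lipophilic compound:
- compound 1 `CC(C)=CCC/C(C)=C/Cn1cc(-c2ccccc2)nn1`: 4.91
- compound 2 `COC(=O)c1cn(C/C=C(\C)CCC=C(C)C)nn1`: 3.2

For the measured compounds named here, of these two compounds, compound 1 stands highest in this assay, and compound 2 is its only neighbour. Compound 3 `CC(C)=CCn1cc(-c2ccccc2)nn1` has not yet been measured. It carries hydrogen in place of 3-methylbut-2-en-1-yl on a saturated chain carbon bound to a double-bonded chain carbon. Going by the values given here, the only measured step, a number 1.71 log units lower from compound 1 to compound 2 (beyond the scatter), is large but falls on an aromatic carbon rather than on this chain. It therefore shows only how far one change can move the number here, and no measurement tests the chain directly. The departing group is carbon-only, with no hydrogen-bond acceptors, so a large move towards a lower number is expected, similar in size to that step. The expected step is a number 1.61 log units lower from compound 1 to compound 3 (beyond the scatter), a fall beyond the scatter. Compound 3 is estimated at 3.3, within a range of 2.9 to 3.7.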

Compound 3, partition coefficient: 2.82
Compound 3: middle estimate off by 0.48 log units, on the high side; measured number below the stated range.
By their numbers in this assay, from the lowest: compound 3; then compound 2; then compound 1.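

In this assay the chain position now has a measurement of its own: hydrogen in place of 3-methylbut-2-en-1-yl on a saturated chain carbon bound to a double-bonded chain carbon gives a number 2.09 log units lower from compound 1 to compound 3 (beyond the scatter) and so places a large step on the chain itself. Before this, the only measured change fell on an aromatic carbon, so the earlier compounds said nothing about how far the number depends on this chain. The departing group has 5 heavy atoms, all carbon, and nothing available explains the size of this step.

The compounds shown leave open how the number would respond to a shorter saturated chain, a longer chain, an amine or a carboxylic acid at this place. They also leave open whether the same change would give a step of similar size with methoxycarbonyl in place of phenyl on the aromatic carbon.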